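The compounds below may be only part of what the source reports. "The series", "measured", "known", "first", "only" and "open" are said of these compounds alone.

Measured compounds and their values in a physicochemical assay for lipophilicity; on this read-out lower numbers stand for lower lipophilicity and higher numbers for higher lipophilicity:

compound 1 `COc1cc(C2SCC(=O)N2NC(=O)CNC(=O)c2ccccc2)cc(OC)c1OC` gives 1.65
compound 2 `O=C(CNC(=O)c1ccccc1)NN1C(=O)CSC1c1ccc(O)cc1` gives 1.75
compound 3 `O=C(CNC(=O)c1ccccc1)NN1C(=O)CSC1c1cccc(Cl)c1` gives 2.8

Compound 3 stands highest of the three in this assay. Its nearest neighbour is compound 2, and the step of a number 1.05 log units higher from compound 2 to compound 3 (beyond the scatter) lies beyond the scatter. For the measured compounds named here, compound 1 is furthest away; its value and that of compound 3 are likewise apart by more than the scatter, and no single-point step connects the two.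

The next compound, compound 4 `O=C(CNC(=O)c1ccccc1)NN1C(=O)CSC1c1ccccc1`, is reached from compound 3 by hydrogen in place of chloro on an aromatic carbon. Of the measured steps only a number 1.05 log units higher from compound 2 to compound 3 (beyond the scatter) touches the same position of the shared core, and there the swap of one group for another at that ring carbon moved this assay by a large amount. The present step is smaller in kind: a substituent is removed and nothing but a hydrogen enters. For compound 4 the expected step is therefore a decrease in this assay, a number 0.70 log units lower from compound 3 to compound 4 (beyond the scatter), clearly beyond the scatter but less than the step from compound 2 to compound 3. Compound 4 is accordingly estimated at 2.1, within a range from 1.7 to 2.5.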

Compound 4, partition coefficient: 1.95
For compound 4 the middle estimate is 0.15 log units above the measured one, within the range that was stated.
By their numbers in this assay, from the lowest: compounds 1, 2 and 4 (each within the scatter of the next); then compound 3.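

With the phenyl of compound 4 as a reference point, the gap at this aromatic carbon in this assay can now be divided into two parts: a number 0.85 log units lower from compound 3 to compound 4 (beyond the scatter) on removal of chloro, and a number 0.20 log units higher from compound 2 to compound 4 (within the scatter) on hydrogen in place of hydroxy. The earlier comparison, a number 1.05 log units higher from compound 2 to compound 3 (beyond the scatter), therefore rests almost wholly on the chloro side, since the 4-hydroxyphenyl of compound 2 and the phenyl of compound 4 are not told apart on this read-out. No supporting measurement is available to explain why the read-out follows the chloro in this way.

As far as these compounds go, the chloro reading rests on one substituent at one place, so it remains open whether bromo, methyl or trifluoromethyl on the same aromatic carbon would give a step of similar size from compound 4. From the compounds shown here alone, it is also open whether an amine or a carboxylic acid there would stay within the scatter of compound 4, as the hydroxy of compound 2 does, or would move away from it in either direction.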